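The source may hold more compounds than are shown below. What is called first, only, known or untested is meant among the compounds shown, and "the series" means these compounds.

Working notes on the shared core of compound 1 `O=C(NCc1ccc(S(=O)(=O)C2CCC(F)(F)CC2)cc1)N1Cc2ccncc2C1`, varied at the sulfonyl sulfur. In an assay on isolated protein for inhibition of Nicotinamide phosphoribosyltransferase (Homo sapiens), read by mass spectrometry, with stated times of 15 min and 30 min (on this read-out higher numbers stand for weaker inhibition and lower numbers for stronger inhibition), compound 1 gives 78 nM. Compound 2 `CN1CCC(S(=O)(=O)c2ccc(CNC(=O)N3Cc4ccncc4C3)cc2)CC1` gives 48 nM in this assay, and compound 3 `O=C(NCc1ccc(S(=O)(=O)N2CCOCC2)cc1)N1Cc2ccncc2C1` gives 71 nM. Compound 3 stands second highest of the three numbers, though its gaps to compound 1 and compound 2 are within the scatter. Compound 4 `O=C(NCc1ccc(S(=O)(=O)N2CCC[C@H](O)C2)cc1)N1Cc2ccncc2C1` carries 3-hydroxypiperidin-1-yl in place of morpholin-4-yl on a sulfonyl sulfur. The steps bearing on this position, a 1.1-fold lower number from compound 1 to compound 3 (0.04 log units; within the scatter) and a 1.5-fold higher number from compound 2 to compound 3 (0.17 log units; within the scatter), were both within the scatter, as was a 1.6-fold lower number from compound 1 to compound 2 (0.21 log units; within the scatter). Every exchange at the sulfonyl sulfur so far has left this assay unmoved beyond the scatter, so no step beyond it is expected here either. Compound 4 is estimated at 70 nM, range 30 nM to 160 nM, an expected step of a 1.0-fold lower number from compound 3 to compound 4 (0.01 log units; within the scatter).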

Compound 4, half-maximal inhibitory concentration: 770 nM
Estimate against measurement, compound 4: 11-fold (1.04 log units) below, and the stated range ends below it.
By their numbers in this assay, from the lowest: compounds 2, 3 and 1 (each within the scatter of the next); then compound 4.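

Within the data shown here, the sulfonyl sulfur is not indifferent in this assay after all: 3-hydroxypiperidin-1-yl gives an 11-fold higher number from compound 3 to compound 4 (1.04 log units; beyond the scatter) and a 16-fold higher number from compound 2 to compound 4 (1.21 log units; beyond the scatter) and also a 9.9-fold higher number from compound 1 to compound 4 (0.99 log units; beyond the scatter) as the only steps at this position beyond the scatter. Against morpholin-4-yl the entering group adds a hydrogen-bond donor and a defined stereocentre, and these two changes arrive together. Nothing measured here accounts for the step.

Open, from the compounds shown here alone, is whether the step follows the hydroxyl, its stereocentre or its place on the ring. The opposite stereoisomer, piperidin-1-yl and 4-hydroxypiperidin-1-yl on the sulfonyl sulfur would each bear on this.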